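A Second Bromo on the Aryl Ring of Compound 2

The compounds below may be only part of what the source reports. "The series", "measured", "known", "first", "only" and "open" are said of these compounds alone.

Compound 2 `Brc1cccc(C2=NCCCC2)c1` gives 29.8 nM in an assay on HEK293 cells for displacement of a labelled ligand from Neuronal acetylcholine receptor; alpha3/beta4 (Homo sapiens), read by radioligand binding, with a stated time of 5 min (a higher number here means a weaker inhibitor, a lower number a stronger inhibitor), the lowest of the three numbers. Compound 1 `OCc1cccc(C2=NCCCC2)c1` gives 80 nM and compound 3 `Fc1cccc(C2=NCCCC2)c1` gives 108 nM in this assay. Both steps into compound 2 lowered the number: a 2.7-fold lower number from compound 1 to compound 2 (0.43 log units; beyond the scatter) and, read the other way, a 3.6-fold higher number from compound 2 to compound 3 (0.56 log units; beyond the scatter). Compound 4 `Brc1cc(Br)cc(C2=NCCCC2)c1` differs from compound 2 by bromo in place of hydrogen on an aromatic carbon, placed meta to a bromo group. Going by the values given here, no measured step swaps a hydrogen for a bromo, so the comparison is indirect; the steps show only that bromo gave the lowest number of the three. A second bromo is therefore expected to keep the number near that of compound 2 or lower it modestly, a step of a 1.5-fold lower number from compound 2 to compound 4 (0.17 log units; within the scatter). Compound 4 is estimated at 20 nM, with a range from 8 nM to 60 nM.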

Compound 4, inhibition constant: 70.8 nM
For compound 4 the middle estimate is 3.5-fold (0.55 log units) below the measured one, and the stated range ends below it.
By their numbers in this assay, from the lowest: compound 2; then compounds 4, 1 and 3 (each within the scatter of the next).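

In this assay bromo in place of hydrogen on this aromatic carbon, meta to a bromo group, brings a 2.4-fold higher number from compound 2 to compound 4 (0.38 log units; beyond the scatter) and so does not extend the low number of compound 2. The earlier compounds shown here showed bromo giving the lowest number of three groups on one aromatic carbon, whereas this step shows that a second bromo on the ring raises the number instead. Nothing given here says why the number rose.

Going by these compounds, whether this rise belongs to bromo itself or would also follow any added group remains open. An amine or a carboxylic acid on this same carbon could tell these apart.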